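The source may hold more compounds than are shown below. What is called first, only, known or untested is meant among the compounds shown, and "the series" means these compounds.

Measured so far:
Compound 1 `Cc1ccccc1OS(=O)(=O)c1ccc(N2CCN(C)C2=O)cc1` gives 4800 nM
Compound 2 `Cc1cccc(OS(=O)(=O)c2ccc(N3CCN(C)C3=O)cc2)c1` gives 4300 nM

Both numbers come from a functional assay on HT-29 cells (Homo sapiens) for antiproliferative activity, read by sulforhodamine B assay, with a stated time of 48 h (a lower number here means a stronger inhibitor, a higher number a weaker inhibitor), and are the only data available. Going by the values given here, the one measured step is a 1.1-fold lower number from compound 1 to compound 2 (0.05 log units; within the scatter), a change in where the methyl group sits, and it stays within the scatter. Compound 2 therefore cannot be told apart from compound 1, and the pair gives no ranking.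

Compound 3 `CN1CCN(c2ccc(S(=O)(=O)Oc3cccc(Br)c3)cc2)C1=O` keeps the rest of compound 2 and differs by bromo in place of methyl on an aromatic carbon. In words, this is bromo in place of methyl on an aromatic carbon, so 3-methylphenyl becomes 3-bromophenyl. Among the compounds with values here, no measured step makes this swap, so the evidence is only indirect. Within the data shown here, the single step above shows that the number held still when the methyl group changed place, but it says nothing direct about bromo. With so little to go on, no shift beyond the scatter is expected in this assay. The expected change is a 1.1-fold lower number from compound 2 to compound 3 (0.05 log units; within the scatter), which is no real move in either direction. For compound 3 the estimate is 3800 nM, with an expected range from 1600 nM to 8500 nM.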

Compound 3, half-maximal inhibitory concentration: 1300 nM
Beside the measured number, compound 3's estimate is 2.9-fold (0.47 log units) above it; measured number outside the range, below it.
By their numbers in this assay, from the lowest: compound 3; then compounds 2 and 1 (each within the scatter of the next).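

In this assay, going from 3-methylphenyl to 3-bromophenyl is the first change among these compounds to move the number beyond the scatter, with a 3.3-fold lower number from compound 2 to compound 3 (0.52 log units; beyond the scatter). The other comparison points the same way, with a 3.7-fold lower number from compound 1 to compound 3 (0.57 log units; beyond the scatter), although this step changes both the group and its place on the ring, so it says less about bromo alone. Moving the methyl group alone had left the number within the scatter, so the new result shows that the identity of the group matters more in this series than the earlier pair could reveal, yet no evidence here accounts for the effect of bromo.

Bromo is the only replacement for methyl shown, so it remains open whether the lower number is specific to bromo or would also appear with chloro, fluoro, methoxy or a nitrile. All three compounds also share the same core, which leaves open whether the effect of bromo would hold if a longer chain or an amine were attached to that core.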